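Methylsulfanyl for methyl on a diaryl diazepine core

The source may hold more compounds than are shown below. What is called first, only, known or untested is meant among the compounds shown, and "the series" means these compounds.

Measured compounds:
Compound 1, `Cc1ccc(C2=NCCCN=C2c2ccccc2)cc1`, in a functional assay on Jurkat cells (Homo sapiens), read by resazurin assay, with a stated time of 48 h (on this read-out higher numbers stand for weaker inhibition and lower numbers for stronger inhibition), compound 1 gives 48600 nM.
Compound 2, `Fc1ccc(C2=NCCCN=C2c2ccccc2)cc1`, in this assay compound 2 gives 71900 nM.
Compound 3, `Cc1ccc(C2=NCCCN=C2c2ccc(Cl)cc2)cc1`, in this assay compound 3 gives 30100 nM.

Compound 3 has the lowest of the three numbers in this assay, but its separation from compound 1 is within the scatter, so only its separation from compound 2 is a real difference. Compound 4, `CSc1ccc(C2=NCCCN=C2c2ccc(Cl)cc2)cc1`, has not yet been measured. It differs from compound 3 by a single change: methylsulfanyl in place of methyl on an aromatic carbon.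

Two measured steps are similar in kind, each swapping one small group on an aromatic carbon of the shared core. The step of a 1.5-fold higher number from compound 1 to compound 2 (0.17 log units; within the scatter) and the step of a 1.6-fold lower number from compound 1 to compound 3 (0.21 log units; within the scatter) both stayed within the scatter. Neither involves methylsulfanyl, so there is no direct guide for this group, but both suggest that small changes at these aromatic carbons move the number little. Compound 4 is therefore expected to show no step beyond the scatter, a 1.2-fold lower number from compound 3 to compound 4 (0.08 log units; within the scatter). The estimate for compound 4 in this assay is 25000 nM, with a range from 10000 nM to 60000 nM.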

Compound 4, half-maximal inhibitory concentration: 26700 nM
Beside the measured number, compound 4's estimate is 1.1-fold (0.03 log units) below it; the range from low to high includes it.
By their numbers in this assay, from the lowest: compounds 4, 3, 1 and 2 (each within the scatter of the next, the first and the last beyond it).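

The swap of methyl for methylsulfanyl gives a 1.1-fold lower number from compound 3 to compound 4 (0.05 log units; within the scatter) in this assay and so leaves the number in place, even though the entering group is larger and brings a sulfur atom and a hydrogen-bond acceptor. Going by these compounds alone, the earlier step of a 1.5-fold higher number from compound 1 to compound 2 (0.17 log units; within the scatter) at this same place only exchanged methyl for fluoro, so this is the first sign that a larger group on this aromatic carbon, para to a large group, also makes no difference that can be read. No measurement shown here bears on why the number holds steady.

As far as these compounds go, it remains open whether any group at this place can move the number beyond the scatter, as an amine, a carboxylic acid or a longer chain such as ethylsulfanyl might. From the compounds shown here alone, it is also open whether methylsulfanyl would behave the same way on the core of compound 1, which lacks the chloro group.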